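A few compounds are considered here, and "the series" means these few. Any claim that something is new, unique, unknown or untested is made for them only; others in the source may bear on it.

Measured so far in the series:

compound 1 `COc1cc(OC)c(C2OC(c3ccc(N(C)C)cc3)=NN2C(C)=O)c(OC)c1` — 40 uM
compound 2 `COc1cc(C2OC(c3ccc(N(C)C)cc3)=NN2C=O)cc(OC)c1OC` — 0.12 uM

In a functional assay on NCI-H460 cells (Homo sapiens) (on this read-out higher numbers stand for an effect only at larger amounts of compound and lower numbers for an effect already at smaller amounts), compound 2 gives 0.12 uM, the lowest of the two numbers obtained. Compound 1 gives 40 uM in this assay; the gap between these two values lies well beyond the scatter. The two compounds differ in more than one place, so no single step can be read from them.

Compound 3 `COc1cc(C2OC(c3ccc(N(C)C)cc3)=NN2C(=O)CN)cc(OC)c1OC` has not been measured in this assay. It is compound 2 with one change, (aminomethyl in place of hydrogen on a carbonyl carbon). Within the data shown here, no measured pair shows this kind of change, so its effect is open. Among the measured compounds shown here, the only guide is that compound 2, the parent, gives 0.12 uM and sits at the low end of what is known.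

The working expectation is a modest move toward a higher number, of a size at or a little beyond the scatter, as the step of a 4.2-fold higher number from compound 2 to compound 3 (0.62 log units; beyond the scatter) expresses. Compound 3 is therefore estimated at 0.5 uM in this assay, with a range from 0.1 uM to 3 uM expected to cover most repeat measurements.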

Compound 3, concentration for half-maximal effect: 0.66 uM
For compound 3 the middle estimate is 1.3-fold (0.12 log units) below the measured one, and the stated range covers the measured number.
By their numbers in this assay, from the lowest: compound 2; then compound 3; then compound 1.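

Within this assay, this is the first step in the series that can be read for a single change: on the carbonyl carbon attached to the amide-type nitrogen in a ring, aminomethyl in place of hydrogen gives a 5.5-fold higher number from compound 2 to compound 3 (0.74 log units; beyond the scatter). The position therefore accepts aminomethyl at a modest but real cost beyond the scatter, and compound 3 still gives 0.66 uM, so substitution on this carbonyl carbon does not abolish the effect in this read-out. Nothing measured here bears on the reason for this step.

One change cannot show whether the shift comes from the amine or simply from replacing hydrogen with a carbon substituent, and compound 1 cannot settle this, since it differs from compound 2 in more than one place. Also open, going by these compounds, is whether a hydroxymethyl group, a dimethylaminomethyl group, a carboxylic acid or a longer chain ending in an amine on this carbonyl carbon would give a number closer to that of compound 2 or further from it.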